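This account rests on a few compounds, and the source may have more. Where it says the series, first, only, none or still open, it means among the compounds named here.

Compound 1, `N=c1c(C(N)=O)cc(Cl)cn1Cc1ccccc1`, is the only one of the three measured compounds for which an assay on CHO-K1 cells for displacement of a labelled ligand from Alpha-1D adrenergic receptor (Homo sapiens), read by scintillation counting, with a stated time of 60 min (a lower number here means a stronger inhibitor, a higher number a weaker inhibitor), returns a number: compound 1 reaches 30 nM. Compound 2, `CCNC(=O)c1cc(Cl)cn(Cc2ccccc2)c1=N`, differs from compound 1 by an ethyl in place of hydrogen on an amide-type nitrogen. In this assay compound 2 gives only a limit, > 940 nM. Compound 3, `CN(C)C(=O)c1cc(Cl)cn(Cc2ccccc2)c1=N`, carries a dimethylamino in place of amino on the carbonyl carbon. In this assay compound 3 likewise gives only a limit, > 940 nM. The step of an at least 31-fold higher number from compound 1 to compound 2 (1.49 log units; beyond the scatter) and the step of an at least 31-fold higher number from compound 1 to compound 3 (1.49 log units; beyond the scatter) both run up against (the limit of > 940 nM in this assay, at which 2 of the 3 values shown sit), and the step that the two limits leave unreadable from compound 2 to compound 3 cannot be read from two limits. Compound 4, `N=c1c(C(N)=O)cc(Br)cn1Cc1ccccc1`, leaves the carbamoyl group of compound 1 untouched; the change is bromo in place of chloro on an aromatic carbon. Going by the values given here, none of the measured steps alters this position, so none of them bears directly on the change. The expectation is therefore a step of no change at the digits printed from compound 1 to compound 4 (within the scatter) that stays within the scatter. Compound 4 is accordingly estimated at 30 nM, within a range from 12 nM to 80 nM.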

Compound 4, inhibition constant: 160 nM
For compound 4 the middle estimate is 5.3-fold (0.73 log units) below the measured one; the whole stated range lies below it.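

The earlier compounds shown here changed only the carbamoyl group, so they said nothing about the halogen position; here, in this assay, bromo in place of chloro gives a 5.3-fold higher number from compound 1 to compound 4 (0.73 log units; beyond the scatter). This swap replaces one heavy atom with one heavy atom and leaves the counts of hydrogen-bond donors and acceptors at zero, yet the change lies beyond the usual scatter, so the identity of the halogen at this position matters in this assay. The compounds shown offer no measured property that explains this step.

With only chloro and bromo compared at this position, two points give no trend that could be carried to other groups. Going by these compounds, how fluoro, a methyl group, an amine or plain hydrogen would behave here remains open, as does whether any of them would match or improve on the chloro of compound 1.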